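The source may hold more compounds than are shown below. What is called first, only, known or untested is meant among the compounds shown, and "the series" means these compounds.

In an assay on isolated protein for inhibition of DNA topoisomerase 1 (Homo sapiens), with a stated time of 30 min, tested at 100 uM (on this read-out higher numbers stand for more inhibition at the one concentration tested (going by the name of the read-out) and lower numbers for less inhibition), three compounds have been measured:

compound 1 `Oc1ccc(-c2cc(-c3cccc(O)c3)cc(-c3ccccc3O)n2)cc1`: 8.4%
compound 2 `Oc1ccc(-c2cc(-c3ccc(O)cc3)nc(-c3cccc(O)c3)c2)cc1`: 0%
compound 3 `Oc1ccc(-c2cc(-c3ccccc3O)nc(-c3ccccc3O)c2)cc1`: 3.7%

All three numbers sit low on the scale of this assay. Compound 3 is the point of departure. For the measured compounds named here, its number lies between those of compound 2 and compound 1, but neither gap exceeds the usual scatter of repeated measurements, so the three compounds cannot be told apart on these data; no compound here can be said to give a higher or lower inhibition in this assay than the others.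

Compound 4 `Oc1ccc(-c2cc(-c3ccc(O)cc3)nc(-c3ccccc3O)c2)cc1` has not yet been measured. It differs from compound 3 in one place: 4-hydroxyphenyl in place of 2-hydroxyphenyl on an aromatic carbon. The same atoms are present in both, joined differently. Going by the values given here, no pair of measured compounds shows this change directly, and the three numbers seen so far all cluster within the scatter. Compound 4 is therefore expected to stay in the same low region, and the step of a number 0.2 percentage points lower from compound 3 to compound 4 (within the scatter) is estimated to lie within the scatter rather than beyond it. Compound 4 is expected to give 3.5% in this assay, in an estimated range from 0% to 12%.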

Compound 4, a percentage reported as inhibition, at one concentration (the size of the read-out at that concentration, not a potency): 0%
Beside the measured number, compound 4's estimate is 3.5 percentage points above it; the range from low to high includes it.
By their numbers in this assay, from the lowest: compounds 2, 4, 3 and 1 (each within the scatter of the next).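

At the place next to the ring nitrogen, the data in this assay now hold the hydroxyl at three ring positions of the same hydroxyphenyl group, and 4-hydroxyphenyl in place of 2-hydroxyphenyl gives a number 3.7 percentage points lower from compound 3 to compound 4 (within the scatter) while 2-hydroxyphenyl in place of 3-hydroxyphenyl gives no change at the digits printed from compound 2 to compound 4 (within the scatter) on the same carbon. The further exchange of 4-hydroxyphenyl for 3-hydroxyphenyl on an aromatic carbon gives a number 8.4 percentage points lower from compound 1 to compound 4 (within the scatter), so none of these shifts of the hydroxyl separates the compounds, and all remain in the same low region of the scale. No measurement is at hand that would explain these numbers.

On these data alone, whether plain phenyl, without the hydroxyl, would read any differently at this position remains open. So does whether an aminophenyl group or a carboxylic acid there would give a number beyond the scatter.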